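From Ester to Hydroxypropyl Tail: Expected Cytotoxicity of Compound 4

A few compounds are considered here, and "the series" means these few. Any claim that something is new, unique, unknown or untested is made for them only; others in the source may bear on it.

Compound 1 `CCCCCCCc1cn(C(c2ccccc2)c2cc3cc(Br)ccc3nc2OC)nn1`: 10.5%
Compound 2 `COc1nc2ccc(Br)cc2cc1C(c1ccccc1)n1cc(-c2ccccc2F)nn1`: 7.33%
Compound 3 `CCOC(=O)c1cn(C(c2ccccc2)c2cc3cc(Br)ccc3nc2OC)nn1`: 2.01%

In an ADME assay on SK-OV-3 cells (Homo sapiens) for cytotoxicity, read by sulforhodamine B assay, with a stated time of 48 h, tested at 10 uM (on this read-out higher numbers stand for more inhibition at the one concentration tested (going by the name of the read-out) and lower numbers for less inhibition), compound 3 shows the smallest of the three numbers, but the steps of a number 8.5 percentage points lower from compound 1 to compound 3 (within the scatter) and a number 5.3 percentage points lower from compound 2 to compound 3 (within the scatter) both lie within the scatter, so the three measured compounds cannot be told apart on this read-out. Compound 4 `COc1nc2ccc(Br)cc2cc1C(c1ccccc1)n1cc(CCCO)nn1` differs from compound 3 only by 3-hydroxypropyl in place of ethoxycarbonyl on an aromatic carbon. Going by the values given here, no measured step introduces a 3-hydroxypropyl group; the steps that touch the same aromatic carbon, a number 3.2 percentage points lower from compound 1 to compound 2 (within the scatter), a number 8.5 percentage points lower from compound 1 to compound 3 (within the scatter) and a number 5.3 percentage points lower from compound 2 to compound 3 (within the scatter), all stay within the scatter. Another change at that carbon is therefore expected to give no step beyond the scatter, a number 5 percentage points higher from compound 3 to compound 4 (within the scatter). Compound 4 is expected to give about 7%, between 0% and 18%.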

Compound 4, a percentage reported as inhibition, at one concentration (the size of the read-out at that concentration, not a potency): 13.8%
For compound 4 the middle estimate is 6.8 percentage points below the measured one; the range from low to high includes it.
By their numbers in this assay, from the lowest: compounds 3, 2, 1 and 4 (each within the scatter of the next, the first and the last beyond it).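

Going by these compounds alone, at this aromatic carbon, 3-hydroxypropyl in place of ethoxycarbonyl gives the first step beyond the scatter in this assay (a number 11.8 percentage points higher from compound 3 to compound 4 (beyond the scatter)), though a modest one. The other two new steps (a number 6.5 percentage points higher from compound 2 to compound 4 (within the scatter); a number 3.3 percentage points higher from compound 1 to compound 4 (within the scatter)) stay within the scatter, so 3-hydroxypropyl stands apart only from ethoxycarbonyl, not from 2-fluorophenyl or heptyl. Nothing measured here explains the step. From the compounds shown here alone, whether it depends on the hydroxy group or on the loss of ethoxycarbonyl stays open, as does how a 3-aminopropyl chain or a carboxylic acid would read at this carbon.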